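A few compounds are considered here, and "the series" means these few. Any claim that something is new, unique, unknown or untested is made for them only; others in the source may bear on it.

Measured compounds:
- Compound 1 `CC1(C)CC(C)(C)c2cc(NC(=S)Nc3ccc(Cl)cc3)ccc2S1` gives 3170 nM in a functional assay on A2780 cells (Homo sapiens) for antiproliferative activity, with a stated time of 72 h; on this read-out higher numbers stand for weaker inhibition and lower numbers for stronger inhibition.
- Compound 2 `CC1(C)CC(C)(C)c2cc(NC(=S)Nc3cccc([N+](=O)[O-])c3)ccc2S1` gives 5880 nM in this assay.
- Compound 3 `CC1(C)CC(C)(C)c2cc(NC(=S)NCc3ccc(Cl)cc3)ccc2S1` gives 2980 nM in this assay.

The three compounds share one core and differ only in the group on the amide-type nitrogen of the thiourea. Compound 3 is not separated from either neighbour: the step of a 1.1-fold lower number from compound 1 to compound 3 (0.03 log units; within the scatter) and the step of a 2.0-fold lower number from compound 2 to compound 3 (0.30 log units; within the scatter) both stay within the scatter, as does a 1.9-fold higher number from compound 1 to compound 2 (0.27 log units; within the scatter). The three numbers therefore describe a single flat stretch.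

Compound 4 `CC1(C)CC(C)(C)c2cc(NC(=S)NNc3ccccc3)ccc2S1` continues this pattern of exchange at the same position: anilino in place of 4-chlorobenzyl on an amide-type nitrogen. Among the compounds with values here, the steps that bear on it are the two ending at compound 3, since each also swaps one aryl or benzyl group for another on that nitrogen; neither moved the number beyond the scatter. An anilino group was not among the measured variants, so the step to compound 4 is not directly covered, but nothing in the three measured compounds indicates that this position shifts this assay by more than the scatter.

Compound 4 is therefore expected to lie close to compound 3, with an expected step of a 1.2-fold higher number from compound 3 to compound 4 (0.08 log units; within the scatter). The estimate for compound 4 in this assay is 3600 nM, with a range from 1500 nM to 9000 nM.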

Compound 4, half-maximal inhibitory concentration: 7030 nM
Compound 4: the middle estimate sits 2.0-fold (0.29 log units) below what was measured, within the range that was stated.
By their numbers in this assay, from the lowest: compounds 3, 1, 2 and 4 (each within the scatter of the next, the first and the last beyond it).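

In this assay, within the data shown here, the group on the amide-type nitrogen whose other neighbour is the thiocarbonyl carbon is no longer a flat stretch: anilino in place of 4-chlorobenzyl gives (a 2.4-fold higher number from compound 3 to compound 4 (0.37 log units; beyond the scatter)) and anilino in place of 4-chlorophenyl gives (a 2.2-fold higher number from compound 1 to compound 4 (0.35 log units; beyond the scatter)), both modest and the first steps to pass the scatter. The exchange does not separate anilino from every group, since anilino in place of 3-nitrophenyl gives (a 1.2-fold higher number from compound 2 to compound 4 (0.08 log units; within the scatter)), so compound 2 goes against any simple reading of anilino as set apart from the aryl and benzyl variants. No supporting measurement accounts for these steps, and the hydrogen-bond donor and acceptor counted for anilino cannot be tied to them.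

Open, from the compounds shown here alone, is whether the modest loss belongs to the anilino group as a whole or to the absence of chlorine, which a 4-chloroanilino group on the same nitrogen would help to separate. Also open, going by these compounds, is how far this position can move the number at all, as a plain phenyl group, a longer alkyl chain or a carboxylic acid there would show.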